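Amine Swap on a Diaryl Ether Core: Expecting Compound 4

The source may hold more compounds than are shown below. What is called first, only, known or untested is meant among the compounds shown, and "the series" means these compounds.

Measured so far:
compound 1 `COc1cc(Oc2cccc(Nc3ccccc3)c2)cc(OC)c1CNCc1ccccc1` gives 5020 nM
compound 2 `CNCc1c(OC)cc(Oc2cccc(Nc3ccccc3)c2)cc1OC` gives 8930 nM
compound 3 `COc1cc(Oc2cccc(Nc3ccccc3)c2)cc(OC)c1CN[C@H](C)c1ccccc1` gives 7550 nM

These three share one core and differ only in the group on the amine nitrogen. They were compared in a functional assay on HCT-15 cells (Homo sapiens) for inhibition, read by MTT assay, with a stated time of 72 h; on this read-out higher numbers stand for weaker inhibition and lower numbers for stronger inhibition. Compound 3 gives the second highest number of the three, but all three lie within the scatter of one another: the step of a 1.8-fold higher number from compound 1 to compound 2 (0.25 log units; within the scatter) and the step of a 1.5-fold higher number from compound 1 to compound 3 (0.18 log units; within the scatter) are both within the scatter, and so is a 1.2-fold lower number from compound 2 to compound 3 (0.07 log units; within the scatter). In other words, taking the phenyl off, or adding a methyl next to the amine, has not moved the read-out beyond what repeat measurements would show anyway.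

Compound 4 `CCN1CCN(Cc2c(OC)cc(Oc3cccc(Nc4ccccc4)c3)cc2OC)CC1` is the next step from compound 3. The change is 4-ethylpiperazin-1-yl in place of (1-phenylethyl)amino on a saturated chain carbon bound to an aromatic carbon. Going by the values given here, no measured step swaps the whole amine for a ring of this kind, so the closest guide is the general picture that changes at this amine have, so far, stayed within the scatter. On that basis the step of a 1.1-fold higher number from compound 3 to compound 4 (0.03 log units; within the scatter) is expected to be small, with no direction beyond the scatter. Compound 4 is therefore estimated at 8000 nM in this assay, within a range of 3000 nM to 22000 nM.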

Compound 4, half-maximal inhibitory concentration: 5090 nM
For compound 4 the middle estimate is 1.6-fold (0.20 log units) above the measured one; measured number inside the range.
By their numbers in this assay, from the lowest: compounds 1, 4, 3 and 2 (each within the scatter of the next).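

In this assay the open-chain amine can be exchanged for a ring without leaving the scatter: 4-ethylpiperazin-1-yl in place of (1-phenylethyl)amino gives a 1.5-fold lower number from compound 3 to compound 4 (0.17 log units; within the scatter), in place of methylamino it gives a 1.8-fold lower number from compound 2 to compound 4 (0.24 log units; within the scatter) and in place of benzylamino it gives a 1.0-fold higher number from compound 1 to compound 4 (0.01 log units; within the scatter). Going by these compounds alone, this is new for the group on the saturated chain carbon bound to an aromatic carbon: the earlier compounds all keep a hydrogen-bond donor on the amine, while 4-ethylpiperazin-1-yl has 0 hydrogen-bond donors and brings a six-membered non-aromatic ring with 2 hetero atoms, yet all four compounds remain within the scatter of one another. The data shown offer no explanation for this result.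

The compounds shown leave open whether any group at this place can move the number beyond the scatter, for example a carboxylic acid or an amide in place of the amine. They also leave open how much the shared core matters, since all four compounds carry it unchanged, so the effect of replacing its methoxy groups with chlorine atoms cannot be judged.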